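The source may report more compounds than this note shows. Statements on the series, on what has been measured and on what is new or still open speak of the compounds shown alone.

Measured compounds in a functional assay on HT-29 cells (Homo sapiens) for inhibition, read by luminescence and CellTiter-Glo, with a stated time of 24 h; on this read-out lower numbers stand for an effect already at smaller amounts and higher numbers for an effect only at larger amounts of compound:
- Compound 1 `CCCCn1nc(C(=O)N[C@H]2COc3ccccc3N(C)C2=S)nc1Cc1ccccc1`: 510 nM
- Compound 2 `CCCCCn1nc(C(=O)N[C@H]2COc3ccccc3N(C)C2=S)nc1Cc1ccccc1`: 805 nM
- Compound 3 `COCCn1nc(C(=O)N[C@H]2COc3ccccc3N(C)C2=S)nc1Cc1ccccc1`: 566 nM

Compound 2 has the highest of these three numbers, yet a 1.6-fold higher number from compound 1 to compound 2 (0.20 log units; within the scatter) and a 1.4-fold lower number from compound 2 to compound 3 (0.15 log units; within the scatter) both lie within the scatter, so the three compounds cannot be told apart on this assay.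

Compound 4 `CN1C(=S)[C@@H](NC(=O)c2nc(Cc3ccccc3)n(CCCCCC#N)n2)COc2ccccc21` differs from compound 2 in one place: cyano in place of hydrogen on a saturated chain carbon, five bonds along the chain from an aromatic nitrogen. The new group brings one triple bond outside aromatic rings and one hydrogen-bond acceptor. For the measured compounds named here, no measured step adds such a group; the measured steps only alter the chain end, and a 1.6-fold higher number from compound 1 to compound 2 (0.20 log units; within the scatter) together with a 1.1-fold higher number from compound 1 to compound 3 (0.05 log units; within the scatter) show such chain changes staying within the scatter. The expectation is therefore a 1.0-fold lower number from compound 2 to compound 4 (0.00 log units; within the scatter), nothing beyond the scatter. Compound 4 is estimated at 800 nM, between 350 nM and 1800 nM.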

Compound 4, half-maximal effective concentration: 3830 nM
For compound 4 the middle estimate is 4.8-fold (0.68 log units) below the measured one, and the stated range ends below it.
By their numbers in this assay, from the lowest: compounds 1, 3 and 2 (each within the scatter of the next); then compound 4.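

Adding cyano five bonds along the chain from the aromatic nitrogen gives a 4.8-fold higher number from compound 2 to compound 4 (0.68 log units; beyond the scatter) in this assay and is the first change on this chain to lie beyond the scatter. Compound 4 also stands apart from the other two chains, with a 6.8-fold higher number from compound 3 to compound 4 (0.83 log units; beyond the scatter) and a 7.5-fold higher number from compound 1 to compound 4 (0.88 log units; beyond the scatter) on the same side. Nothing measured here says why the number rises.

On these data alone, it remains open whether only the nitrile does this or whether an amine or a carboxylic acid in the same place would do the same. As far as these compounds go, a shorter chain such as 3-cyanopropyl also remains open.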